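Three Limits Before a Benzyl Swap

A few compounds are considered here, and "the series" means these few. Any claim that something is new, unique, unknown or untested is made for them only; others in the source may bear on it.

Compound 1 `CCOC(=O)CN(Cc1ccccc1)c1nc(NCc2ccccc2)ncc1[N+](=O)[O-]` is one of three measured compounds. In a functional assay on A549 cells (Homo sapiens) for antiproliferative activity, read by MTT assay, with a stated time of 48 h (on this read-out higher numbers stand for weaker inhibition and lower numbers for stronger inhibition), compound 1 gives > 100000 nM, which is a limit of the assay. Compound 2 `CCOC(=O)CNc1nc(Nc2ccccc2)ncc1[N+](=O)[O-]` is the second. In this assay compound 2 gives > 100000 nM, again a limit. Compound 3 `CCOC(=O)CNc1nc(Nc2ccc(Cl)cc2)ncc1[N+](=O)[O-]` is the third. In this assay compound 3 gives > 100000 nM, also a limit.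

Compound 3 therefore stands where every measured value stands: at the limit of > 100000 nM in this assay, at which 3 of the 3 values shown sit. Among the measured compounds shown here, the only single-point step among the measured compounds, a step that the two limits leave unreadable from compound 2 to compound 3, cannot be read in size, since both ends are limits.

The next compound, compound 4 `CCOC(=O)CNc1nc(NCc2ccccc2)ncc1[N+](=O)[O-]`, differs from compound 3 by benzyl in place of 4-chlorophenyl on a nitrogen on an aromatic ring. For the measured compounds named here, compound 1 already carries a benzyl on the same nitrogen, alongside a second benzyl on the other nitrogen, and it sits at the same limit as compound 3, so no measured step offers a readable size for this change.

On that basis compound 4 is expected to remain at the limit, with a step of a number no higher from compound 3 to compound 4 (the limit leaves the size open) that is expected to show no change beyond the scatter. The estimate for compound 4 in this assay is 100000 nM, expected to lie between 30000 nM and 300000 nM.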

Compound 4, half-maximal inhibitory concentration: 74400 nM
For compound 4 the middle estimate is 1.3-fold (0.13 log units) above the measured one, and the stated range covers the measured number.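

In this assay compound 4 gives 74400 nM, the only number among the compounds shown that is not a limit. The other three compounds all stand at a limit of the assay: the limit of > 100000 nM in this assay, at which 3 of the 4 values shown sit.

Against those limits, benzyl in place of 4-chlorophenyl on a nitrogen on an aromatic ring gives an at least 1.3-fold lower number from compound 3 to compound 4 (0.12 log units; that floor lies within the scatter), benzyl in place of phenyl gives an at least 1.3-fold lower number from compound 2 to compound 4 (0.12 log units; that floor lies within the scatter), and hydrogen in place of benzyl on that nitrogen gives an at least 1.3-fold lower number from compound 1 to compound 4 (0.12 log units; that floor lies within the scatter); each of these is only a floor, so a benzylamino group at this position with the other nitrogen left carrying hydrogen yields a readable value, while the true sizes of the three steps stay unknown.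

The compounds shown leave open whether a chloro on the ring of the benzyl group, or a longer chain such as phenethyl in its place, would move the number further from the limit in this assay. They also leave open what a carboxylic acid or an amide in place of the ethyl ester would do on the shared core.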